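Swapping the Aryl Group on a Piperazine Nitrogen

This account rests on a few compounds, and the source may have more. Where it says the series, first, only, none or still open, it means among the compounds named here.

Three compounds share one core and differ only in the group on an amine nitrogen in a ring. Compound 1 `CC(C)N1CCN(Cc2csc(N)c2C(=O)c2ccc(Cl)cc2)CC1` gives -7.4% in a functional assay on CHO cells with adenosine receptor A1 (Homo sapiens) as the target, read by cAMP accumulation and immunoassay, with a stated time of 6 min, tested at 10 uM; on this read-out lower numbers stand for a stronger effect and higher numbers for a weaker effect at the one concentration tested. Compound 2 `Nc1scc(CN2CCN(c3ccc(Cl)cc3F)CC2)c1C(=O)c1ccc(Cl)cc1` gives -81% in this assay, and compound 3 `COc1ccc(N2CCN(Cc3csc(N)c3C(=O)c3ccc(Cl)cc3)CC2)cc1` gives -52%. Compound 3 thus stands second highest of the three: a number 29 percentage points higher from compound 2 to compound 3 (beyond the scatter), while a number 44.6 percentage points lower from compound 1 to compound 3 (beyond the scatter) and a number 73.6 percentage points lower from compound 1 to compound 2 (beyond the scatter).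

Compound 4 `Nc1scc(CN2CCN(c3ccc(Cl)c(C(F)(F)F)c3)CC2)c1C(=O)c1ccc(Cl)cc1` is the next step from compound 3: 4-chloro-3-(trifluoromethyl)phenyl in place of 4-methoxyphenyl on an amine nitrogen in a ring. The step that bears most directly on it is the one between the two aryl-bearing compounds, a number 29 percentage points higher from compound 2 to compound 3 (beyond the scatter), a modest step; the two steps from isopropyl to an aryl group were large. Because compound 2 gives -81% with a halogenated aryl group, a modest downward step is expected for compound 4, a number 18 percentage points lower from compound 3 to compound 4 (beyond the scatter). Compound 4 is therefore estimated at -70%, with a range from -95% to -40%.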

Compound 4, a percentage reported as activity, at one concentration (the size of the read-out at that concentration, not a potency): -60%
Beside the measured number, compound 4's estimate is 10 percentage points below it, and the stated range covers the measured number.
By their numbers in this assay, from the lowest: compound 2; then compounds 4 and 3 (each within the scatter of the next); then compound 1.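

In this assay, the step of a number 8 percentage points lower from compound 3 to compound 4 (within the scatter) shows that this position accepts two quite different aryl groups, one with a methoxy group and one with chlorine and trifluoromethyl, with no readable difference between them. Halogens on the phenyl ring do not by themselves fix the number, as compound 2 and compound 4 both carry them and still show a number 21 percentage points higher from compound 2 to compound 4 (beyond the scatter) in the same assay, while replacing isopropyl with the new aryl group remains a large change (a number 52.6 percentage points lower from compound 1 to compound 4 (beyond the scatter)). Nothing measured here explains these differences.

The compounds shown leave open how an unsubstituted phenyl group or a cyclohexyl ring would behave on this nitrogen. They also leave open whether a single chlorine or a single trifluoromethyl group on the phenyl ring would match either halogenated compound.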